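A few compounds are considered here, and "the series" means these few. Any claim that something is new, unique, unknown or untested is made for them only; others in the source may bear on it.

Measured compounds:
- compound 1, `O=C1NC(c2ccccc2)CN1c1cnn2c1CN(C(=O)Nc1cc(F)c(F)c(F)c1)C(C1CC1)C2`: 38500 nM
- compound 2, `O=C1CC(Oc2ncc(F)cn2)CN1c1cnn2c1CN(C(=O)Nc1cc(F)c(F)c(F)c1)C(C1CC1)C2`: 96200 nM
- compound 3, `O=C1CC(C(F)(F)F)CN1c1cnn2c1CN(C(=O)Nc1cc(F)c(F)c(F)c1)C(C1CC1)C2`: 115000 nM

In a toxicity assay on HepG2 2.2.15 cells (Homo sapiens) for cytotoxicity, read by CellTiter-Glo (a lower number here means that less compound is tolerated, a higher number that more compound is tolerated), compound 2 stands second highest of the three numbers; it sits close to compound 3, while compound 1 sits further off. Compound 4, `O=C1CC(c2nccs2)CN1c1cnn2c1CN(C(=O)Nc1cc(F)c(F)c(F)c1)C(C1CC1)C2`, has not yet been measured. It differs from compound 2 in one place: 1,3-thiazol-2-yl in place of (5-fluoropyrimidin-2-yl)oxy on a saturated ring carbon. The step that bears most directly on this change is the one at the same saturated ring carbon, a 1.2-fold higher number from compound 2 to compound 3 (0.08 log units; within the scatter), which stayed within the scatter. The other step, a 3.0-fold higher number from compound 1 to compound 3 (0.48 log units; beyond the scatter), concerns a different place and is only modest. A change at this position is therefore expected to leave this assay roughly unchanged, with a 1.2-fold lower number from compound 2 to compound 4 (0.08 log units; within the scatter) expected. Compound 4 is estimated at 80000 nM, in the range 35000 nM to 180000 nM.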

Compound 4, half-maximal cytotoxic concentration: 115000 nM
Beside the measured number, compound 4's estimate is 1.4-fold (0.16 log units) below it; low and high end bracket the measured number.
By their numbers in this assay, from the lowest: compound 1; then compounds 2, 3 and 4 (each within the scatter of the next).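

In this assay the saturated ring carbon now carries a third kind of group with no readable shift, with a 1.2-fold higher number from compound 2 to compound 4 (0.08 log units; within the scatter) and no change at the digits printed from compound 3 to compound 4 (within the scatter) both inside the scatter. So 1,3-thiazol-2-yl, (5-fluoropyrimidin-2-yl)oxy and trifluoromethyl all read alike here, despite their different rings and atoms. The larger change stays with the other place, in the step of a 3.0-fold higher number from compound 1 to compound 4 (0.48 log units; beyond the scatter) that replaces the whole 2-oxo-4-phenylimidazolidin-1-yl group. No measured evidence explains why these groups read alike. From the compounds shown here alone, whether an amine or a carboxylic acid on this carbon would also read alike remains open.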